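Cyclopropyl in Place of Pyridin-3-yl

A few compounds are considered here, and "the series" means these few. Any claim that something is new, unique, unknown or untested is made for them only; others in the source may bear on it.

In an ADME assay on microsomes from liver (Homo sapiens) for metabolic stability, using NADPH, with a stated time of 10 min (on this read-out lower numbers stand for a less stable compound and higher numbers for a more stable compound), compound 1 `CCCCc1nc(=O)c(S(=O)(=O)c2ccc(-c3cccnc3)cc2)c(O)n1-c1c(OC)cccc1OC` gives 88%. Compound 2 `CCCCc1[nH]c(=O)c(S(=O)(=O)c2ccc(-c3ccncc3C)cc2)c(O)c1-c1c(OC)cccc1OC` gives 80%, a number within the scatter of compound 1. Compound 3 `CCCCc1[nH]c(=O)c(S(=O)(=O)c2ccc(-n3ccccc3=O)cc2)c(O)c1-c1c(OC)cccc1OC` gives 100%. Its number is the higher one, and the gap to compound 1 lies beyond that scatter. Compound 4 `CCCCc1nc(=O)c(S(=O)(=O)c2ccc(C3CC3)cc2)c(O)n1-c1c(OC)cccc1OC` keeps the core of compound 1 but carries cyclopropyl in place of pyridin-3-yl on an aromatic carbon. Going by the values given here, only one measured step swaps a single group, and it does so on a different core: a number 20 percentage points higher from compound 2 to compound 3 (beyond the scatter). That step is modest and involves no cyclopropyl, so it offers only weak guidance, and no shift beyond the scatter is expected. The estimated step is a number 5 percentage points lower from compound 1 to compound 4 (within the scatter). For compound 4 the expected value is 83%, with an estimated range from 68% to 98%.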

Compound 4, percent of the compound remaining: 95%
For compound 4 the middle estimate is 12 percentage points below the measured one; the measured number falls inside the stated range.
By their numbers in this assay, from the lowest: compounds 2, 1, 4 and 3 (each within the scatter of the next, the first and the last beyond it).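

Going by these compounds alone, this is the first step on the core of compound 1 at this place, on an aromatic carbon of a six-membered aromatic ring of carbon only, and it exchanges one ring for another. In this assay cyclopropyl in place of pyridin-3-yl gives a number 7 percentage points higher from compound 1 to compound 4 (within the scatter), so a three-membered carbon ring serves here as well as the larger aromatic ring containing nitrogen. Nothing available explains this result.

Still open, from the compounds shown here alone, is how an open-chain group such as tert-butyl or an amine such as morpholine would fare at this place. Going by these compounds, whether cyclopropyl would give a similar result on the core of compound 2 also remains unknown.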